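The source may hold more compounds than are shown below. What is called first, only, known or untested is meant among the compounds shown, and "the series" means these compounds.

Measured so far:

Compound 1, `COC(=O)c1cc(-n2cc(-c3cc(OC)cc(OC)c3)nn2)ccc1O`, 3%
Compound 2, `COc1cc(OC)cc(-c2cn(-c3ccc(O)c(C(=O)O)c3)nn2)c1`, 2%
Compound 3, `COC(=O)c1cc(-n2cc(-c3cccc(O)c3)nn2)ccc1O`, 6%

All three were tested in a functional assay on HCT-116 cells (Homo sapiens) for inhibition, read by MTT assay, with a stated time of 2 days, tested at 10 uM; a higher number here means more inhibition at the concentration tested (going by the name of the read-out), a lower number less inhibition. Compound 1 and compound 2 differ in one place only: hydrogen in place of methyl on an oxygen next to a carbonyl group. That change produced a number 1 percentage points lower from compound 1 to compound 2 (within the scatter), so the two numbers cannot be told apart. Compound 3 is built on a different core from compound 1; the difference between the two cores is not broken down here. Compound 3 has the highest of the three numbers, yet its distances to compound 1 and to compound 2 both lie within the scatter, so no ranking among them can be drawn.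

Compound 4, `O=C(O)c1cc(-n2cc(-c3cccc(O)c3)nn2)ccc1O`, has not yet been measured in this assay. It differs from compound 3 by hydrogen in place of methyl on an oxygen next to a carbonyl group, the same change that turned compound 1 into compound 2, at the same kind of place. The step from compound 3 to compound 4 is therefore expected to be small, a number 2 percentage points lower from compound 3 to compound 4 (within the scatter), because a number 1 percentage points lower from compound 1 to compound 2 (within the scatter) stayed within the scatter. On that basis compound 4 is estimated at 4%, with a plausible span from 0% to 12%.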

Compound 4, a percentage reported as inhibition, at one concentration (the size of the read-out at that concentration, not a potency): 5%
The estimate for compound 4 lay 1 percentage points below the measured number; the range from low to high includes it.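

Changing methoxycarbonyl to carboxy on the core of compound 3 gave a number 1 percentage points lower from compound 3 to compound 4 (within the scatter) in this assay. Set beside the earlier case, the change looks the same on both cores: the same change on two cores in this assay, a number 1 percentage points lower (within the scatter) from compound 1 to compound 2 and a number 1 percentage points lower (within the scatter) from compound 3 to compound 4, 0 percentage points apart, within the scatter of two such steps This shows that, for these two cores, swapping the methyl for hydrogen moved the number by no more than the usual scatter, but it does not show that the change is harmless everywhere, as two cores are few and all four compounds give only small numbers, so a core with strong inhibition might respond differently.

The compounds shown leave open what an amide, or an ethyl group in place of the methyl, would give at this spot. With only one concentration tested, they also leave open whether any of the four compounds would inhibit these cells more clearly at a higher concentration.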